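A few compounds are considered here, and "the series" means these few. Any claim that something is new, unique, unknown or untested is made for them only; others in the source may bear on it.

Measured so far:
Compound 1 `O=S(=O)(O)OCCCCCCCCCCCC[Te]c1ccccc1`: 4960 nM
Compound 2 `O=S(=O)(O)OCCCCCCCCC[Se]c1ccccc1`: > 100000 nM

Both compounds were tested in a functional assay on RAW264.7 cells (Mus musculus) for cytotoxicity, read by MTT assay, with a stated time of 24 h; a higher number here means a weaker inhibitor, a lower number a stronger inhibitor. Compound 2 gives only a limit of the assay, > 100000 nM, and not a number.

Compound 3 `O=S(=O)(O)OCCCCCCCCC[Te]c1ccccc1` differs from compound 2 in one place: a group of 7 heavy atoms (6 carbon, 1 tellurium; one six-membered aromatic ring of carbon only) in place of a group of 7 heavy atoms (6 carbon, 1 selenium; one six-membered aromatic ring of carbon only), on a saturated chain carbon, nine bonds along the chain from an oxygen. In plain terms, tellurium stands where selenium stood, and the rest of the molecule stays the same.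

Among the compounds with values here, no measured pair shows this change on its own. The nearest guide is compound 1, which also carries tellurium but on a longer chain, and compound 1 gives a true number, 4960 nM. On that basis, a clear step towards stronger inhibition is expected in this assay, although the difference in chain length leaves its size uncertain. The expected change is an at least 8.3-fold lower number from compound 2 to compound 3 (0.92 log units; beyond the scatter). The value of compound 3 is estimated at 12000 nM, with an expected range of 3500 nM to 50000 nM.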

Compound 3, half-maximal inhibitory concentration: 4670 nM
Estimate against measurement, compound 3: 2.6-fold (0.41 log units) above, and the stated range covers the measured number.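

In this assay, tellurium in place of selenium at this spot on the chain gives an at least 21-fold lower number from compound 2 to compound 3 (1.33 log units; beyond the scatter) and so counts as a large change even with the other parts of the molecule held the same. For compound 2 the figure is a limit and not a number, so this step gives only a minimum size: the limit of > 100000 nM in this assay, at which 1 of the 3 values shown sits.

The chain shows something different: a 1.1-fold lower number from compound 1 to compound 3 (0.03 log units; within the scatter) lies within the scatter, so with tellurium in place, the chains of compound 1 and compound 3 cannot be told apart in this assay.

Open, as far as these compounds go, is how selenium would fare on the longer chain of compound 1, and whether sulfur in that same spot would follow tellurium or selenium. Also open, from the compounds shown here alone, is whether a much shorter chain, or a carboxylic acid in place of the sulfooxy group, would keep the activity seen with tellurium.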